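A few compounds are considered here, and "the series" means these few. Any claim that something is new, unique, unknown or untested is made for them only; others in the source may bear on it.

Measured so far:
Compound 1 `COc1ncnc2c1c(-c1cccs1)cn2[C@@H]1O[C@H](CO)[C@@H](O)[C@H]1O` gives 43200 nM in an ADME assay on MRC5 cells (Homo sapiens), read by MTT assay, with a stated time of 72 h; a higher number here means a weaker inhibitor, a lower number a stronger inhibitor.
Compound 2 `CSc1ncnc2c1c(-c1cccs1)cn2[C@@H]1O[C@H](CO)[C@@H](O)[C@H]1O` gives > 100000 nM in this assay, which is a limit of the assay and not a number.
Compound 3 `C#Cc1cn([C@@H]2O[C@H](CO)[C@@H](O)[C@H]2O)c2ncnc(OC)c12` gives > 100000 nM in this assay, again a limit of the assay and not a number.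

Compound 2 differs from compound 1 by methylsulfanyl in place of methoxy on an aromatic carbon, and that change made an at least 2.3-fold higher number from compound 1 to compound 2 (0.36 log units; beyond the scatter). Compound 3 differs from compound 1 in its core by ethynyl in place of thiophen-2-yl on an aromatic carbon, a change that made an at least 2.3-fold higher number from compound 1 to compound 3 (0.36 log units; beyond the scatter). Both steps end at the limit of > 100000 nM in this assay, at which 2 of the 3 values shown sit.

Compound 4 `C#Cc1cn([C@@H]2O[C@H](CO)[C@@H](O)[C@H]2O)c2ncnc(SC)c12` has not been measured. It differs from compound 3 by methylsulfanyl in place of methoxy on an aromatic carbon, the same change as the one between compound 1 and compound 2; it occurs twice among these compounds, and the place is described in the same words both times.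

For compound 3 to compound 4 in this assay a step that the limit leaves unreadable from compound 3 to compound 4 is expected, because the same change gave an at least 2.3-fold higher number from compound 1 to compound 2 (0.36 log units; beyond the scatter) and compound 3 already sits at the limit of > 100000 nM in this assay, at which 2 of the 3 values shown sit. Compound 4 is therefore estimated at 150000 nM, within 80000 nM to 400000 nM, most likely reported only as a limit.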

Compound 4, half-maximal inhibitory concentration: > 100000 nM
Compound 4 gave a limit, no number; the forecaster's own chance of this, stated with the estimate: 90%; the middle value does not contradict the limit.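

No new step can be read for compound 4, because its result is a limit and not a number, and compound 2 and compound 3 sit at that same limit: the limit of > 100000 nM in this assay, at which 3 of the 4 values shown sit.

The compounds shown leave open how far apart compound 2, compound 3 and compound 4 really lie, and how much methylsulfanyl in place of methoxy changes the number when ethynyl is present.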